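Quinolinone Amides: From Acetylphenyl to Ethynyl Substituent

The source may hold more compounds than are shown below. What is called first, only, known or untested is meant among the compounds shown, and "the series" means these compounds.

Measured compounds:
Compound 1, `O=C(Nc1ccc(C(F)(F)F)cc1)c1cc(=O)[nH]c2cc(Br)ccc12`, > 20000 nM
Compound 2, `O=C(Nc1cc(F)cc(F)c1)c1cc(=O)[nH]c2cc(F)ccc12`, > 20000 nM
Compound 3, `CC(=O)c1ccc(-c2ccc3c(C(=O)Nc4cccc(F)c4)cc(=O)[nH]c3c2)cc1`, > 20000 nM

In a functional assay on KYSE-70 cells for antiproliferative activity against KYSE-70 cell line (Homo sapiens), read by MTT assay, with a stated time of 72 h (on this read-out lower numbers stand for stronger inhibition and higher numbers for weaker inhibition), compound 1 gives only a limit, > 20000 nM, and no number. In this assay compound 2 likewise stops at a limit, > 20000 nM. Compound 3, the compound of interest here, also returns only a limit in this assay, > 20000 nM, so its true position among the numbers cannot be told. For the measured compounds named here, all three measured values rest on the same mark, (the limit of > 20000 nM in this assay, at which 3 of the 3 values shown sit), and no step between any two of them can be sized.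

Compound 4, `C#Cc1ccc2c(C(=O)Nc3cccc(F)c3)cc(=O)[nH]c2c1`, differs from compound 3 in one place: ethynyl in place of 4-acetylphenyl on an aromatic carbon. Going by the values given here, no measured step shows how such a change moves this assay, so the expectation for the step from compound 3 to compound 4 is that it stays within the scatter, a step that the limit leaves unreadable from compound 3 to compound 4. Compound 4 is therefore expected to give about 25000 nM in this assay, in a range from 8000 nM to 80000 nM, most likely again reported only as a limit.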

Compound 4, half-maximal inhibitory concentration: 9500 nM
The estimate for compound 4 lay 2.6-fold (0.42 log units) above the measured number, within the range that was stated.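

On this aromatic carbon, ethynyl in place of 4-acetylphenyl brings an at least 2.1-fold lower number from compound 3 to compound 4 (0.32 log units; beyond the scatter) in this assay, the first change among the compounds shown that can be seen to move the read-out. Compound 4, at 9500 nM, is the only one of the four to give a number rather than a limit, so this position can affect the result and the large 4-acetylphenyl group is not required for a measurable value. The step is only a minimum because compound 3 itself gives no number: the limit of > 20000 nM in this assay, at which 3 of the 4 values shown sit.

The compounds shown leave open whether a nitrile, an amine or an ethynyl group carrying a longer chain would give a similar number at this position. Nothing here separates the effect of the entering triple bond from that of the departing aromatic ring.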